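Working notes on a group exchange at the shared core

This account rests on a few compounds, and the source may have more. Where it says the series, first, only, none or still open, it means among the compounds named here.

Measured so far in a physicochemical assay for lipophilicity, using the shake flask method; on this read-out lower numbers stand for lower lipophilicity and higher numbers for higher lipophilicity:
- compound 1 `Cc1cnc(-c2cc(Oc3ccc(S(C)(=O)=O)cc3)cc(OC(C)C)c2)[nH]c1=O` gives 2.68
- compound 2 `Cc1cc(=O)[nH]c(-c2cc(Oc3ccc(S(C)(=O)=O)cc3)cc(OC(C)C)c2)n1` gives 2.43

Only these two numbers exist, and compound 2, at 2.43, stands within the scatter of compound 1. The next change leads to compound 3 `COc1cnc(-c2cc(Oc3ccc(S(C)(=O)=O)cc3)cc(OC(C)C)c2)[nH]c1=O` and is a group of 9 heavy atoms (5 carbon, 2 nitrogen, 2 oxygen; one six-membered aromatic ring with 2 hetero atoms) in place of a group of 8 heavy atoms (5 carbon, 2 nitrogen, 1 oxygen; one six-membered aromatic ring with 2 hetero atoms), on an aromatic carbon. Among the measured compounds shown here, the one measured step bearing on it is a number 0.25 log units lower from compound 1 to compound 2 (within the scatter), an exchange of one group of this ring type for another. For the measured compounds named here, no measured step shows a change in the size of the group. With that single step as the guide, no step beyond the scatter is expected in this assay. The expected step is a number 0.07 log units higher from compound 2 to compound 3 (within the scatter). Compound 3 is estimated at 2.5, with an expected range of 2.15 to 2.85.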

Compound 3, distribution coefficient: 2.21
For compound 3 the middle estimate is 0.29 log units above the measured one, and the stated range covers the measured number.
By their numbers in this assay, from the lowest: compounds 3, 2 and 1 (each within the scatter of the next, the first and the last beyond it).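

Methoxy in place of methyl on an aromatic carbon gives a number 0.47 log units lower from compound 1 to compound 3 (beyond the scatter) in this assay, the first step beyond the scatter in this series, and it shows that a single exchange at this carbon can separate two compounds on this read-out. The exchange of the whole group gives a number 0.22 log units lower from compound 2 to compound 3 (within the scatter), so compound 2 cannot be told apart from compound 3, just as it could not be told apart from compound 1. No measured data on the series offer an account of the methyl to methoxy step.

On these data alone, whether the step carries over to other groups at this carbon, such as ethoxy, a chlorine atom or an amine, stays open. Also open, as far as these compounds go, is whether methoxy in place of methyl within the group of compound 2 gives a step of similar size.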